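Formyl for methyl: from compound 2 to compound 3

The source may report more compounds than this note shows. Statements on the series, on what has been measured and on what is new or still open speak of the compounds shown alone.

In a functional assay on MDA-MB-231 cells (Homo sapiens) for antiproliferative activity, read by thymidine incorporation, with a stated time of 3 days (a lower number here means a stronger inhibitor, a higher number a weaker inhibitor), compound 1 `COc1ccc(-n2c(C)c(C)c(C)c2-c2cc(OC)c(OC)c(OC)c2)cc1O` gives 1660 nM as a measured number. Compound 2 `COc1ccc(-c2c(C)c(C)c(C)n2-c2cc(OC)c(OC)c(OC)c2)cc1O` stands at >= 10000 nM in this assay as a limit of the assay, not a number. Compound 3 `COc1ccc(-c2c(C)c(C)c(C=O)n2-c2cc(OC)c(OC)c(OC)c2)cc1O` carries formyl in place of methyl on an aromatic carbon, next to the ring nitrogen (formyl in place of methyl on an aromatic carbon), and awaits measurement. Going by the values given here, no measured step covers this change, so only a modest move toward stronger inhibition in this assay is expected, with an at least 1.2-fold lower number from compound 2 to compound 3 (0.09 log units; that floor lies within the scatter) as the estimated step and a fair chance of another limit reading. Compound 3 is estimated at 8000 nM with an expected range from 1500 nM to 30000 nM around it.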

Compound 3, half-maximal inhibitory concentration: >= 10000 nM
Compound 3: only a limit was reported (the forecaster's own chance of this, stated with the estimate: 50%); middle value at least 1.2-fold (0.09 log units) from the limit.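

No step can be read from compound 2 to compound 3, because both compounds stand at a limit of the assay, not a number: the limit of >= 10000 nM in this assay, at which 2 of the 3 values shown sit.

The compounds shown leave open whether formyl in place of methyl on an aromatic carbon changes inhibition at all, and in which direction.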